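The source may report more compounds than this note shows. Statements on the series, on what has been measured and on what is new or still open speak of the compounds shown alone.

Working notes on the series.

Compound 3 `C[C@@H]1O[C@H](C2CCCCC2)C([Si](C)(C)C)=C(Cl)[C@H]1C` gives 20000 nM in a functional assay on SW1573 cells (Homo sapiens) for antiproliferative activity (on this read-out higher numbers stand for weaker inhibition of growth and lower numbers for stronger inhibition of growth), the highest of the three numbers, yet within the scatter of both its neighbours: compound 1 `C[C@H]1CC(Cl)=C([Si](C)(C)C)[C@@H](C2CCCCC2)O1` gives 16000 nM and compound 2 `C[C@H]1CC(Cl)=C[C@@H](C2CCCCC2)O1` gives 12000 nM. The two measured steps, a 1.3-fold lower number from compound 1 to compound 2 (0.12 log units; within the scatter) and a 1.3-fold higher number from compound 1 to compound 3 (0.10 log units; within the scatter), are both within the scatter, so neither the group of four heavy atoms on the double-bonded ring carbon nor the methyl on the saturated ring carbon shifts the read-out in this assay.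

Compound 4 `C=CCC[C@H]1O[C@@H](C)[C@H](C)C(Cl)=C1[Si](C)(C)C` follows from compound 3 by but-3-en-1-yl in place of cyclohexyl on a saturated ring carbon. For the measured compounds named here, no measured step concerns this saturated ring carbon; the two steps available touch other groups and were both flat. From the compounds shown here alone, with nothing to suggest otherwise, the expectation is no step beyond the scatter, no change at the digits printed from compound 3 to compound 4 (within the scatter), but the range is widened because the change is untested.

Compound 4 is therefore estimated at 20000 nM in this assay, expected to lie between 8000 nM and 50000 nM.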

Compound 4, concentration for 50% growth inhibition: 23000 nM
Estimate against measurement, compound 4: 1.2-fold (0.06 log units) below; low and high end bracket the measured number.
By their numbers in this assay, from the lowest: compounds 2, 1, 3 and 4 (each within the scatter of the next).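

At the saturated ring carbon next to the ring oxygen, the six-membered carbon ring of cyclohexyl gives way to the open but-3-en-1-yl chain with a 1.2-fold higher number from compound 3 to compound 4 (0.06 log units; within the scatter) in this assay. This position therefore tolerates the loss of the ring and the entry of a double bond without a shift beyond the scatter, and it joins the two earlier changes as a third flat step. No independent measurement bears on why the read-out stays flat here.

From the compounds shown here alone, whether any group at this carbon can move the number remains open: an amine, a carboxylic acid or a longer chain could test this. The compounds shown include no step beyond the scatter, so none of their differences identifies a feature of the series that governs growth inhibition.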